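Urea series: cycloalkyl replacement at the amide nitrogen

The compounds below may be only part of what the source reports. "The series", "measured", "known", "first", "only" and "open" are said of these compounds alone.

Measured compounds in a functional assay on the whole organism for inhibition, with Rattus norvegicus as the target, at a dose of 30 mg/kg by the oral route; a higher number here means more inhibition at the dose given (going by the name of the read-out), a lower number less inhibition:
compound 1 `CN(C(=O)NCCCOc1ccc2nc(O)ccc2c1)C1CCCCC1` gives 15%
compound 2 `O=C(NCCCOc1ccc2nc(O)ccc2c1)N(C1CC1)[C@@H]1CCC[C@H]1O` gives 23%
compound 3 `CN(C(=O)NCCCOc1ccc2nc(O)ccc2c1)[C@@H]1CCCC[C@H]1O` gives 10%

Compound 2 has the highest of the three numbers in this assay. Its nearest neighbour is compound 1, which lies within the scatter of it; compound 3 lies beyond the scatter below it, so only that one gap counts as a difference.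

Compound 4 `CCCCO[C@H]1CCCC[C@@H]1N(C(=O)NCCCOc1ccc2nc(O)ccc2c1)C1CC1` has not been measured. Against compound 2 the change is 2-butoxycyclohexyl in place of 2-hydroxycyclopentyl on an amide-type nitrogen.

Going by the values given here, one measured step bears on part of this change. From compound 1 to compound 3 a hydroxy replaces hydrogen on a saturated ring carbon, and the result is a number 5 percentage points lower from compound 1 to compound 3 (within the scatter). That step runs in the opposite sense to the loss of the hydroxy here and stayed within the scatter, so the removal of the hydroxy alone is not expected to move the number. Among the compounds with values here, for the change from a five-membered to a six-membered ring and for the entering butoxy there is no measured step at all.

The expected step from compound 2 to compound 4 in this assay is therefore none beyond the scatter, a number 3 percentage points lower from compound 2 to compound 4 (within the scatter). Compound 4 is estimated at 20%, within 5% to 35%.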

Compound 4, a percentage reported as inhibition, in the whole organism at one dose (the size of the read-out at that dose, not a potency): 19%
Compound 4: middle estimate off by 1 percentage points, on the high side; low and high end bracket the measured number.
By their numbers in this assay, from the lowest: compounds 3, 1, 4 and 2 (each within the scatter of the next, the first and the last beyond it).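

Working notes: in this assay, a much larger group fits on this amide-type nitrogen, as 2-butoxycyclohexyl in place of 2-hydroxycyclopentyl gives a number 4 percentage points lower from compound 2 to compound 4 (within the scatter) in this pair. The earlier compounds shown here showed only a hydroxy entering a saturated ring, whereas this pair shows that a group with 0 hydrogen-bond donors, a six-membered ring and 11 heavy atoms can replace one with 1 donor, a five-membered ring and 6 heavy atoms without a change beyond the scatter. There is no measured account of why the number holds across this change, and the ring size, the loss of the hydroxy and the entry of the butoxy cannot be separated within this single step.

Still open, as far as these compounds go, is whether each of these parts has no effect on its own or whether opposing effects cancel, which a 2-methoxycyclohexyl or 2-hydroxycyclohexyl group on the same nitrogen would help to separate. Also open, from the compounds shown here alone, is whether an amine, a carboxylic acid or a longer alkoxy chain in place of the butoxy would move the number beyond the scatter in this assay at this position.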